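This account rests on a few compounds, and the source may have more. Where it says the series, first, only, none or still open, it means among the compounds named here.

In an ADME assay (liver) for metabolic stability, with Liver microsome (Homo sapiens) as the target, read by LC-MS, using microsomes and NADPH, with a stated time of 5 min, at 37 degrees C (a higher number here means faster removal of the compound, a lower number slower removal), two compounds sharing one core have been measured so far. Compound 1 (`CCn1c([C@@H](C)NS(=O)(=O)c2ccc(C)cc2)nc2ccc(C(F)(F)F)cc21`) reads > 100 mL.min-1.g-1, which is a limit of the assay and not a number. Compound 2 (`CCn1c([C@@H](C)NS(=O)(=O)c2ccccn2)nc2ccc(C(F)(F)F)cc21`) reads < 3 mL.min-1.g-1, also a limit, and it stands at the slow-removal end of the two results, with its true value unseen.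

The next structure, compound 3 (`CCn1cc(S(=O)(=O)N[C@H](C)c2nc3ccc(C(F)(F)F)cc3n2CC)cn1`), changes one group: 1-ethyl-1H-pyrazol-4-yl in place of pyridin-2-yl on a sulfonyl sulfur. Among the measured compounds shown here, one measured step bears on this place, the swap of 4-methylphenyl for pyridin-2-yl, and it was large: an at least 33-fold lower number from compound 1 to compound 2 (1.52 log units; beyond the scatter). The group on the sulfonyl sulfur can therefore move this read-out strongly, though a single step shows nothing about how a pyrazole will behave.

Compound 2 rests at < 3 mL.min-1.g-1, a limit, so a visible step in this assay can only be toward a higher number, and a moderate one is expected. The expected change is an at least 3.3-fold higher number from compound 2 to compound 3 (0.52 log units; beyond the scatter). For compound 3 the estimate is 10 mL.min-1.g-1, with an expected range from 3 mL.min-1.g-1 to 40 mL.min-1.g-1.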

Compound 3, intrinsic clearance in microsomes: 95 mL.min-1.g-1
Estimate against measurement, compound 3: 9.5-fold (0.98 log units) below; the whole stated range lies below it.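

In this assay, a ring carrying hetero atoms on the sulfonyl sulfur does not by itself go with a low number: exchanging the pyridin-2-yl of the slowly removed compound for 1-ethyl-1H-pyrazol-4-yl gives an at least 31-fold higher number from compound 2 to compound 3 (1.50 log units; beyond the scatter). That step is only a floor, because compound 2 rests at a limit of the assay and not at a number: the limit of < 3 mL.min-1.g-1 in this assay, at which 1 of the 3 values shown sits. Putting the same pyrazole group in place of 4-methylphenyl gives an at least 1.0-fold lower number from compound 1 to compound 3 (0.02 log units; that floor lies within the scatter), and no order can be drawn from this floor, because the starting compound of that step also rests at a limit and not at a number: the limit of > 100 mL.min-1.g-1 in this assay, at which 1 of the 3 values shown sits.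

The ring and its ethyl chain enter together in one step, and the compounds shown do not tell which of the two goes with the higher number. Going by these compounds, how a pyrazole with a methyl group in place of the ethyl chain, or a pyrimidine ring, would read on the sulfonyl sulfur stays open, and so does the true size of all these steps.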